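The compounds below may be only part of what the source reports. "The series", "measured", "known", "first", "only" and "open" are said of these compounds alone.

Going by the values given here, in a functional assay on MDA-MB-231 cells (Homo sapiens) for antiproliferative activity, read by MTT assay (on this read-out lower numbers stand for stronger inhibition and higher numbers for weaker inhibition), compound 1 `CCCCC/C=C\C/C=C\CCCCCCCc1cc(=O)c2c(O)cc(O)c(C)c2o1` gives 6790 nM, the only true number among the compounds tested so far. Compound 2 `CCCCC1(O)CC(=O)c2c(O)cc(O)cc2O1` is recorded only as a limit, > 87000 nM. Among the compounds with values here, the two compounds therefore offer no measured step to work from, and compound 1 serves as the reference point. Compound 3 `CCCCCCCCCCCCCCCc1cc(=O)c2c(O)cc(O)c(C)c2o1` has not yet been measured. It shares the core of compound 1 and differs only in the long chain: octyl in place of deca-1,4-dien-1-yl on a saturated chain carbon, seven bonds along the chain from an aromatic carbon, with octyl in place of deca-1,4-dien-1-yl on a saturated chain carbon, seven bonds along the chain from an aromatic carbon. Within the data shown here, the long chain stays in place, and no measured pair shows this change on its own. The expected result in this assay is therefore a modest move toward weaker inhibition, a 1.8-fold higher number from compound 1 to compound 3 (0.25 log units; within the scatter). Compound 3 is estimated at 12000 nM, with an expected range of 4000 nM to 40000 nM.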

Compound 3, half-maximal inhibitory concentration: 6790 nM
Compound 3: the middle estimate sits 1.8-fold (0.25 log units) above what was measured; low and high end bracket the measured number.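

In this assay, the step from the deca-1,4-dien-1-yl to the octyl end of the long chain, on a saturated chain carbon, seven bonds along the chain from an aromatic carbon, gives no change at the digits printed from compound 1 to compound 3 (within the scatter). Going by these compounds alone, this is the first measured step, and it shows that, for this pair, the two double bonds outside aromatic rings and the two further carbons can leave together with no change in the read-out. Nothing given here offers a cause for this result.

This single step changes chain length and double bonds at once, and the compounds shown do not separate the two. They also leave open whether an amine or a carboxylic acid on the chain, or a much shorter chain, would keep this level of inhibition.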